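This account rests on a few compounds, and the source may have more. Where it says the series, first, only, none or still open, it means among the compounds named here.

Compound 1 `CCCN1C(=O)NC2(CSC3=C2C(=O)c2ccccc2C3=O)C1=O` has been measured in a functional assay on SW-620 cells (Homo sapiens) for inhibition (a lower number here means a stronger inhibitor, a higher number a weaker inhibitor), where compound 1 gives 379 nM; this is the only number shown for it, and one further entry for it carries no single number. Compound 2 `NCCN1C(=O)NC2(CSC3=C2C(=O)c2ccccc2C3=O)C1=O` gives 35 nM; 34 nM; 47 nM (3 entries) in this assay. Compound 3 `NCCCN1C(=O)NC2(CSC3=C2C(=O)c2ccccc2C3=O)C1=O` has not yet been measured. It differs from compound 1 by amino in place of hydrogen on a saturated chain carbon, three bonds along the chain from an amide-type nitrogen in a ring. Compound 2 also carries an amino group on its chain, and its repeated entries the several entries of compound 2 in this assay, 35 nM; 34 nM; 47 nM (3 entries) sit at a lower number than compound 1. The step from compound 1 to compound 3 is therefore expected to be a 7.6-fold lower number from compound 1 to compound 3 (0.88 log units; beyond the scatter), toward stronger inhibition. Compound 3 is expected to give 50 nM, within a range from 15 nM to 160 nM.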

Compound 3, half-maximal inhibitory concentration: 52 nM
Beside the measured number, compound 3's estimate is 1.0-fold (0.02 log units) below it, and the stated range covers the measured number.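

In this assay, changing propyl to 3-aminopropyl gives a 7.3-fold lower number from compound 1 to compound 3 (0.86 log units; beyond the scatter), so a real gain from the amino group now appears on this three-carbon chain. Until now, an amino group on this chain had been seen only in compound 2, which carries a different chain, 2-aminoethyl: the several entries of compound 2 in this assay, 35 nM; 34 nM; 47 nM (3 entries)

The compounds shown leave open how a longer chain, such as 4-aminobutyl, would read. They also leave open whether a dimethylamino group, a hydroxyl group or a carboxylic acid on the propyl chain would read like the amino group.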